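This account rests on a few compounds, and the source may have more. Where it says the series, first, only, none or still open, it means among the compounds named here.

Measured so far:
Compound 1, `Cc1ccccc1CNc1nn(-c2ccc(F)cc2F)cc1CNCCN1CCN(C)CC1`. In an ADME assay on Huh-7 cells (Homo sapiens) for cytotoxicity (a lower number here means that less compound is tolerated, a higher number that more compound is tolerated), compound 1 gives > 20000 nM, which is a limit of the assay and not a number.
Compound 2, `CN1CCN(CCNCc2cn(-c3ccc(F)cc3F)nc2-c2ccc(OC(F)(F)F)cc2)CC1`. In this assay compound 2 gives 18000 nM.
Compound 3, `CN1CCN(CCNCc2cn(-c3ccc([N+](=O)[O-])cc3)nc2-c2ccc(OC(F)(F)F)cc2)CC1`. In this assay compound 3 gives 4400 nM.

Compound 2 holds the highest of the two numbers in this assay; its nearest neighbour is compound 3, reached by a 4.1-fold lower number from compound 2 to compound 3 (0.61 log units; beyond the scatter), a change on the aromatic nitrogen. Compound 1 stands apart at the limit of > 20000 nM in this assay, at which 1 of the 3 values shown sits.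

The step to compound 4, `Cc1cccc(-c2nn(-c3ccc(F)cc3F)cc2CNCCN2CCN(C)CC2)c1`, is 3-methylphenyl in place of 4-(trifluoromethoxy)phenyl on an aromatic carbon. Of the measured steps, only an at least 1.1-fold lower number from compound 1 to compound 2 (0.04 log units; that floor lies within the scatter) touches the same aromatic carbon, and it exchanged a quite different group without a change that can be told from the scatter. The step of a 4.1-fold lower number from compound 2 to compound 3 (0.61 log units; beyond the scatter) concerns the group on the aromatic nitrogen and does not bear directly on this exchange.

With one uninformative step at this position and none between two aryl groups there, compound 4 is expected to show no step beyond the scatter in this assay, that is a 1.1-fold higher number from compound 2 to compound 4 (0.05 log units; within the scatter). Compound 4 is therefore estimated at 20000 nM, with a range from 8000 nM to 50000 nM, and a real chance that only a limit is reported.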

Compound 4, half-maximal cytotoxic concentration: > 20000 nM
Compound 4 was reported as a limit; the forecaster's own chance of this, stated with the estimate: 40%; the middle value sits exactly at the limit.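

In this assay, among these compounds, the exchange of 4-(trifluoromethoxy)phenyl for 3-methylphenyl on the aromatic carbon gives an at least 1.1-fold higher number from compound 2 to compound 4 (0.04 log units; that floor lies within the scatter), the first comparison of two aryl groups at this position. Of these two aryl groups, the one with oxygen and fluorine is therefore not needed for a number as high as that of compound 2, and the one with carbon alone brings no drop that can be told from the scatter. Compound 4 joins compound 1 at the limit of the assay, and the step between these two cannot be read: the limit of > 20000 nM in this assay, at which 2 of the 4 values shown sit.

On these data alone, how far compound 4 really lies above this limit remains unknown, so the aryl exchange may be larger than its floor suggests, and any difference from compound 1 stays hidden. Also open, as far as these compounds go, is whether a carboxylic acid or a primary amine on the 3-methylphenyl ring, or a 4-nitrophenyl group on the aromatic nitrogen of compound 4, would bring the number down into the readable range.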